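A few compounds are considered here, and "the series" means these few. Any claim that something is new, unique, unknown or untested is made for them only; others in the source may bear on it.

Measured so far:
- compound 1 `O=C(CSC(=S)N[C@H]1CCOC1=O)Nc1ccc(Br)cc1`; in a functional assay on MGC-803 cells (Homo sapiens) for cytotoxicity, read by MTT assay, with a stated time of 72 h (on this read-out higher numbers stand for weaker inhibition and lower numbers for stronger inhibition), compound 1 gives 42800 nM
- compound 2 `CSC(=S)N[C@H]1CCOC1=O`; in this assay compound 2 reaches only the assay limit > 128000 nM
- compound 3 `CCSC(=S)N[C@H]1CCOC1=O`; in this assay compound 3 likewise reaches only the assay limit > 128000 nM

Compound 3 therefore stands at a limit, not at a number, and only compound 1 carries a measured value. Going by the values given here, the single step that touches compound 3, a step that the two limits leave unreadable from compound 2 to compound 3, cannot be read because the limit of > 128000 nM in this assay, at which 2 of the 3 values shown sit, holds both of its ends. Compound 4 `CCCCSC(=S)N[C@H]1CCOC1=O` differs from compound 3 by ethyl in place of hydrogen on a saturated chain carbon, two bonds along the chain from a sulfur. With no readable step on this kind of change, no shift beyond the scatter is expected; the step that the limit leaves unreadable from compound 3 to compound 4 is estimated as essentially none. Compound 4 is accordingly expected at 150000 nM, with a range from 60000 nM to 400000 nM, most likely again reported only as a limit.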

Compound 4, half-maximal inhibitory concentration: > 128000 nM
Compound 4: only a limit was reported (the forecaster's own chance of this, stated with the estimate: 75%); the middle value lies beyond the limit too.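

Going by these compounds alone, no step from compound 2 or compound 3 to compound 4 can be read, since all three compounds stand at a limit: the limit of > 128000 nM in this assay, at which 3 of the 4 values shown sit. From the compounds shown here alone, whether compound 2, compound 3 and compound 4 differ at all in this assay stays open.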